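The compounds below may be only part of what the source reports. "The series", "measured", "known", "first", "only" and "open" are said of these compounds alone.

In a functional assay on MCF7 cells (Homo sapiens) for cytotoxicity (on this read-out lower numbers stand for stronger inhibition and higher numbers for weaker inhibition), compound 1 `C=C/C=C\[C@H](C)[C@H](OC(N)=O)[C@@H](C)[C@H](O)[C@@H](C)C/C(C)=C\[C@H](C)[C@@H](O)[C@@H](C)/C=C\CCc1cccc(F)c1` gives 370 nM, compound 2 `C=C/C=C\[C@H](C)[C@H](OC(N)=O)[C@@H](C)[C@H](O)[C@@H](C)C/C(C)=C\[C@H](C)[C@@H](O)[C@@H](C)/C=C\CCc1sccc1C` gives 370 nM, and compound 3 `C=C/C=C\[C@H](C)[C@H](OC(N)=O)[C@@H](C)[C@H](O)[C@@H](C)C/C(C)=C\[C@H](C)[C@@H](O)[C@@H](C)/C=C\CCc1ccccc1` gives 480 nM. Compound 3 therefore stands within the scatter of both others. Compound 4 `C=C/C=C\[C@H](C)[C@H](OC(N)=O)[C@@H](C)[C@H](O)[C@@H](C)C/C(C)=C\[C@H](C)[C@@H](O)[C@@H](C)/C=C\CCc1cccc(OC)c1` carries methoxy in place of hydrogen on an aromatic carbon, meta to a large group: methoxy in place of hydrogen on an aromatic carbon. Among the compounds with values here, two measured steps bear on this change. Exchanging fluoro for hydrogen gives a 1.3-fold higher number from compound 1 to compound 3 (0.11 log units; within the scatter), and exchanging the aromatic group gives a 1.3-fold higher number from compound 2 to compound 3 (0.11 log units; within the scatter). Within the data shown here, no measured compound carries methoxy, so these steps offer only indirect guidance, and no shift beyond the scatter is expected. The expected step is a 1.1-fold lower number from compound 3 to compound 4 (0.06 log units; within the scatter). For compound 4 the estimate is 420 nM, with an expected range of 190 nM to 950 nM.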

Compound 4, half-maximal inhibitory concentration: 330 nM
Estimate against measurement, compound 4: 1.3-fold (0.10 log units) above, within the range that was stated.
By their numbers in this assay, from the lowest: compounds 4, 1, 2 and 3 (each within the scatter of the next).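

In this assay, methoxy on this aromatic carbon, meta to a large group, stays within the scatter of hydrogen, with a 1.5-fold lower number from compound 3 to compound 4 (0.16 log units; within the scatter). Methoxy in place of fluoro gives a 1.1-fold lower number from compound 1 to compound 4 (0.05 log units; within the scatter), and 3-methoxyphenyl in place of 3-methylthiophen-2-yl gives a 1.1-fold lower number from compound 2 to compound 4 (0.05 log units; within the scatter), so an oxygen-linked group at this position produces no step beyond the scatter. No measured evidence accounts for these steps.

Still open, from the compounds shown here alone, is whether an amine or a carboxylic acid on this aromatic carbon would give a step beyond the scatter. The same question stands for a longer chain in place of phenethyl.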